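Methyl for chlorophenyl on the sulfonamide of a benzoxazole

The source may hold more compounds than are shown below. What is called first, only, known or untested is meant among the compounds shown, and "the series" means these compounds.

Within the data shown here, compound 1 `O=S(=O)(Nc1ccc2oc(-c3ccccc3)nc2c1)c1cccc(Cl)c1` holds the only numerical value in an ADME assay on HEK293 cells (Homo sapiens) for cytotoxicity, read by resazurin assay, with a stated time of 48 h (on this read-out lower numbers stand for higher toxicity in this test and higher numbers for lower toxicity in this test), where compound 1 gives 70000 nM. Compound 2 `O=S(=O)(Nc1ccc(-c2nc3ccccc3o2)cc1)c1ccc(O)cc1` reaches only the limit of the assay, giving > 100000 nM in this assay, a limit and not a number. Compound 3 `CS(=O)(=O)Nc1ccc2oc(-c3ccccc3)nc2c1` is not yet measured; it differs from compound 1 in one place (methyl in place of 3-chlorophenyl on a sulfonyl sulfur). Among the measured compounds shown here, no measured step is available for this kind of change. The step from compound 1 to compound 3 in this assay is expected to be a 1.7-fold higher number from compound 1 to compound 3 (0.23 log units; within the scatter), toward lower toxicity, and may run into the limit. Compound 3 is estimated at 120000 nM in this assay, within 60000 nM to 250000 nM.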

Compound 3, half-maximal cytotoxic concentration: > 100000 nM
Compound 3 gave a limit, no number; the forecaster's own chance of this, stated with the estimate: 55%; the middle value does not contradict the limit.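

The change gives an at least 1.4-fold higher number from compound 1 to compound 3 (0.15 log units; that floor lies within the scatter) in this assay, the first step read at this position. Compound 3 gives a limit and not a number, so the position can carry methyl in place of 3-chlorophenyl with no measurable toxicity in this test. How far the step really runs cannot be read, because the read-out ends there: the limit of > 100000 nM in this assay, at which 2 of the 3 values shown sit.

Open, from the compounds shown here alone, is whether the chlorine or the whole ring accounts for the value of compound 1, which an unsubstituted phenyl on the sulfonyl sulfur would separate. Also open, going by these compounds, is whether an amine or a longer alkyl chain there would give a number.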